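The source may report more compounds than this note shows. Statements on the series, on what has been measured and on what is new or still open speak of the compounds shown alone.

Measured in a functional assay on A549 cells (Homo sapiens) for antiproliferative activity, read by MTT assay, with a stated time of 48 h; a lower number here means a stronger inhibitor, a higher number a weaker inhibitor
- compound 1 `C=C(c1ccc(OC)cc1NC(=O)CN)c1ccc(OC)c2c1OC(C)(C)C=C2` gives 50 nM
- compound 2 `C=C(c1ccc(OC)cc1NC(=O)CNC)c1ccc(OC)c2c1OC(C)(C)C=C2` gives 150 nM

Compound 2 gives 150 nM and holds the higher of the two numbers, which makes it the weaker inhibitor of the pair. Next is compound 3 `C=C(c1ccc(OC)cc1NC(=O)CNCC)c1ccc(OC)c2c1OC(C)(C)C=C2`, which differs from compound 2 by methyl in place of hydrogen on a saturated chain carbon bound to an amine nitrogen, turning methylamino into ethylamino.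

Within the data shown here, only one measured step bears on this change, a 3.0-fold higher number from compound 1 to compound 2 (0.48 log units; beyond the scatter), and it was modest. That step put methyl on the amine nitrogen itself, whereas the new methyl goes on the chain carbon bound to that nitrogen, so the precedent is only partial. On that single step, a further modest rise in the number is expected in this assay, rather than a fall. The expected change is a 1.9-fold higher number from compound 2 to compound 3 (0.27 log units; within the scatter) as estimated from this one precedent. Compound 3 is estimated at 280 nM as the middle value, with an expected range from 100 nM to 800 nM in this assay.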

Compound 3, half-maximal inhibitory concentration: 970 nM
Compound 3: the middle estimate sits 3.5-fold (0.54 log units) below what was measured; the whole stated range lies below it.
By their numbers in this assay, from the lowest: compound 1; then compound 2; then compound 3.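

In this assay, the series now has two consecutive steps beyond the scatter along the same amine: the first step (a 3.0-fold higher number from compound 1 to compound 2 (0.48 log units; beyond the scatter)) is followed by the change from methylamino to ethylamino (a 6.5-fold higher number from compound 2 to compound 3 (0.81 log units; beyond the scatter)), so methyl in place of hydrogen on the saturated chain carbon bound to the amine nitrogen is not a neutral change. Read from the unsubstituted amine, ethyl in place of hydrogen on the amine nitrogen gives a large step (a 19-fold higher number from compound 1 to compound 3 (1.29 log units; beyond the scatter)), and among these three compounds the number rises with each added carbon, with no compound going against that order and compound 1 remaining the strongest inhibitor at 50 nM. No measurement available here accounts for this rise.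

Open, on these data alone, is whether a propyl group or a longer chain on the amine nitrogen would raise the number further or level it off. Also open, as far as these compounds go, is how a dimethylamino group, or a branched isopropyl group on that nitrogen, would compare with the methylamino and ethylamino compounds in this assay.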